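Trimming the ester from compound 3 to a plain methyl

The source may hold more compounds than are shown below. What is called first, only, known or untested is meant among the compounds shown, and "the series" means these compounds.

Measured so far:
compound 1, `C/C(=N\Nc1nc(-c2ccc(Br)cc2)cs1)c1cc2ccccc2o1`: 33200 nM
compound 2, `C/C(=N\Nc1nc(-c2ccc(Cl)cc2)cs1)c1cc2ccccc2o1`: 29900 nM
compound 3, `CCOC(=O)Cc1csc(N/N=C(\C)c2cc3ccccc3o2)n1`: 6550 nM

All three compounds share one core and were tested in a functional assay on MCF7 cells (Homo sapiens) for antiproliferative activity; a higher number here means a weaker inhibitor, a lower number a stronger inhibitor. Compound 1 gives 33200 nM and compound 2 gives 29900 nM; the step of a 1.1-fold lower number from compound 1 to compound 2 (0.05 log units; within the scatter) is within the scatter. Compound 3, with 6550 nM, gives the lowest number of the three: the steps of a 5.1-fold lower number from compound 1 to compound 3 (0.70 log units; beyond the scatter) and a 4.6-fold lower number from compound 2 to compound 3 (0.66 log units; beyond the scatter) are both beyond the scatter, modest in size, and both replace an aryl group with the (ethoxycarbonyl)methyl chain.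

Compound 4, `C/C(=N\Nc1nc(C)cs1)c1cc2ccccc2o1`, differs from compound 3 by hydrogen in place of ethoxycarbonyl on a saturated chain carbon bound to an aromatic carbon. For the measured compounds named here, no measured step removes the ethoxycarbonyl alone, so the two steps into compound 3 bear only indirectly: they show that the (ethoxycarbonyl)methyl group goes with the lowest number, without saying whether its ester part or simply the absence of the aryl group matters. A modest rise in the number back toward compounds 1 and 2, or no change beyond the scatter, is expected; the estimated step is a 1.8-fold higher number from compound 3 to compound 4 (0.26 log units; within the scatter). For compound 4 the estimate in this assay is 12000 nM, within the range 4000 nM to 40000 nM.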

Compound 4, half-maximal inhibitory concentration: 4890 nM
The estimate for compound 4 lay 2.5-fold (0.39 log units) above the measured number; the measured number falls inside the stated range.
By their numbers in this assay, from the lowest: compounds 4 and 3 (each within the scatter of the next); then compounds 2 and 1 (each within the scatter of the next).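

In this assay, cutting (ethoxycarbonyl)methyl back to methyl gives a 1.3-fold lower number from compound 3 to compound 4 (0.13 log units; within the scatter), so the ester part can go without a change that stands out from the scatter. For the compounds shown here, this settles what the earlier steps could not: the ester is not required for the lower number, since a plain methyl also gives a 6.1-fold lower number from compound 2 to compound 4 (0.79 log units; beyond the scatter) in place of 4-chlorophenyl and a 6.8-fold lower number from compound 1 to compound 4 (0.83 log units; beyond the scatter) in place of 4-bromophenyl. Among these four compounds, the higher numbers therefore belong to the two with a halogen-bearing phenyl ring, while the methyl and (ethoxycarbonyl)methyl compounds cannot be told apart.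

No supporting data explain this difference. The compounds shown leave open how a carboxylic acid or an amine on the chain, a longer plain carbon chain, or a phenyl ring without a halogen would compare.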